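A few compounds are considered here, and "the series" means these few. Any claim that something is new, unique, unknown or untested is made for them only; others in the source may bear on it.

Compound 1 `CC(C)C(CC1C(=O)NC(=O)N1C)c1ccc(-c2ccc3cccc(F)c3c2)[nH]c1=O` has no exact number in an ADME assay on microsomes from liver (Rattus norvegicus) for metabolic stability; a lower number here means that the compound disappears faster, a higher number that the compound lasts longer: its result, < 0.0667 h, is a limit of the assay. Going by the values given here, the only other measured compound, compound 2 `CC(C)[C@@H](c1ccc(-c2ccc3cccc(F)c3c2)[nH]c1=O)[C@@H]1OC(=O)NC1=O`, gives 1.27 h in this assay. Compound 3 `CC(C)C(c1ccc(-c2ccc3cccc(F)c3c2)[nH]c1=O)C1SC(=O)NC1=O` differs from compound 1 at a single place (2,4-dioxo-1,3-thiazolidin-5-yl in place of (3-methyl-2,5-dioxoimidazolidin-4-yl)methyl on a saturated chain carbon bound to an aromatic carbon and a saturated chain carbon). It carries 2,4-dioxo-1,3-thiazolidin-5-yl in place of (3-methyl-2,5-dioxoimidazolidin-4-yl)methyl, on a saturated chain carbon bound to an aromatic carbon and a saturated chain carbon. Among the compounds with values here, no measured pair shows this exact change, so any forecast is rough. A longer half-life, beyond the usual scatter, is expected. Compound 2 reaches 1.27 h with the same shared core. The estimated size of the change is an at least 5.9-fold higher number from compound 1 to compound 3 (0.77 log units; beyond the scatter). Compound 3 is expected to give 0.4 h, within an estimated range of 0.1 h to 1.5 h.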

Compound 3, half-life: 0.76 h
The estimate for compound 3 lay 1.9-fold (0.28 log units) below the measured number, and the stated range covers the measured number.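

In this assay, putting 2,4-dioxo-1,3-thiazolidin-5-yl in place of (3-methyl-2,5-dioxoimidazolidin-4-yl)methyl on this saturated chain carbon gives an at least 11-fold higher number from compound 1 to compound 3 (1.05 log units; beyond the scatter), the first single-place step seen at this position. This size is a minimum rather than an exact figure, because compound 1 stands at a limit of the assay and not at a number: the limit of < 0.0667 h in this assay, at which 1 of the 3 values shown sits.

Two things change together in this step, the ring and the methyl link named in the leaving group, so the step cannot be credited to either one alone. As far as these compounds go, it remains open whether 2,4-dioxo-1,3-thiazolidin-5-yl would give a similar half-life if attached through a methyl link. Also open, from the compounds shown here alone, is how a simpler group on this carbon, such as a carboxylic acid or an amine, would behave in this assay.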